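Two Five-Membered Rings on a Saturated Ring Carbon

The compounds below may be only part of what the source reports. "The series", "measured", "known", "first", "only" and "open" are said of these compounds alone.

Measured so far:
compound 1 `C/C(=C\C(=O)Nc1ccc2nc(N3CCC(O)(C4CC4)CC3)nc(C)c2c1)c1ccc(Cl)cc1` gives 340 nM
compound 2 `Cc1nc(N2CCC(N3CCCS3(=O)=O)CC2)nc2ccc(NC(=O)/C=C/c3ccc(OC(F)(F)F)cc3)cc12` gives 16 nM

In a functional assay on CHO-K1 cells for antagonist activity at melanin-concentrating hormone receptor 1 (Homo sapiens), read by inositol phosphate accumulation, with stated times of 10 min and 45 min (on this read-out higher numbers stand for weaker inhibition and lower numbers for stronger inhibition), compound 2 has the lowest number of the two, and its nearest neighbour, compound 1, sits at a number far enough above it to lie beyond the scatter. Compound 3 `Cc1nc(N2CCC(N3CCN(C)C3=O)CC2)nc2ccc(NC(=O)/C=C/c3ccc(OC(F)(F)F)cc3)cc12` is not yet measured. It differs from compound 2 in one place: a group of 7 heavy atoms (4 carbon, 2 nitrogen, 1 oxygen; one five-membered non-aromatic ring with 2 hetero atoms) in place of a group of 7 heavy atoms (3 carbon, 1 nitrogen, 2 oxygen, 1 sulfur; one five-membered non-aromatic ring with 2 hetero atoms), on a saturated ring carbon. The group that leaves has no common name; the group that enters is 3-methyl-2-oxoimidazolidin-1-yl, and both sit on a saturated ring carbon of the six-membered non-aromatic ring with one nitrogen. For the measured compounds named here, no step between measured compounds exists to guide this change, so the expectation rests on compound 2 alone. The step from compound 2 to compound 3 is expected to be small, a 1.6-fold higher number from compound 2 to compound 3 (0.19 log units; within the scatter), within or only just beyond the scatter, with a weak lean toward a higher number. Compound 3 is therefore expected to give about 25 nM in this assay, in a range from 8 nM to 80 nM.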

Compound 3, half-maximal inhibitory concentration: 21 nM
Beside the measured number, compound 3's estimate is 1.2-fold (0.08 log units) above it, within the range that was stated.
By their numbers in this assay, from the lowest: compounds 2 and 3 (each within the scatter of the next); then compound 1.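

For the compounds shown here, the first step that can be read at this position is a 1.3-fold higher number from compound 2 to compound 3 (0.12 log units; within the scatter) in this assay, so it gives a first direct comparison on this saturated ring carbon, three ring bonds from the ring nitrogen. There, 3-methyl-2-oxoimidazolidin-1-yl, with no sulfur and 1 hydrogen-bond acceptor, cannot be told apart from the sulfur-bearing five-membered ring of compound 2, which has 2 hydrogen-bond acceptors. Nothing measured here speaks to why these two groups read alike.

The compounds shown leave open how this carbon responds to groups other than these two five-membered rings, such as a primary amine, a carboxylic acid or an open-chain urea. Compound 1 differs from both in more than one place, so it cannot answer that question.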